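The source may hold more compounds than are shown below. What is called first, only, known or untested is meant among the compounds shown, and "the series" means these compounds.

Measured so far:
Compound 1, `CCc1ccccc1NC(=O)N[C@H](C)c1ccccc1`: in an ADME assay on the whole organism with Oryza sativa as the target, tested at 0.1 uM (a higher number here means a weaker effect of the compound at the concentration tested, a lower number a stronger effect), compound 1 gives 101%.
Compound 2, `C[C@@H](NC(=O)Nc1ccccc1C(C)(C)C)c1ccccc1`: in this assay compound 2 gives 100%.
Compound 3, `C[C@H](NC(=O)Nc1ccccc1C(C)(C)C)c1ccccc1`: in this assay compound 3 gives 101%.

Compound 2 has the lowest of the three numbers, yet both other readings lie within the scatter of it, so all three compounds show the same weak effect at this concentration. The step of a number 1 percentage points lower from compound 1 to compound 2 (within the scatter) did not move the read-out. The step of a number 1 percentage points higher from compound 2 to compound 3 (within the scatter), which is consistent with the fact that compounds 2 and 3 differ only in the configuration as drawn, did not move it either.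

Compound 4, `CC(=O)c1ccccc1NC(=O)N[C@H](C)c1ccccc1`, differs from compound 2 by acetyl in place of tert-butyl on an aromatic carbon. Among the compounds with values here, no measured step swaps in an acetyl, so the two steps already seen only show that a change at this position and a change of configuration both left the read-out within scatter. On that basis a step of a number 1 percentage points lower from compound 2 to compound 4 (within the scatter) is expected, meaning no change beyond the scatter. Compound 4 is estimated at 99% in this assay, with a range from 84% to 106%.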

Compound 4, a percentage reported as activity, at one concentration (the size of the read-out at that concentration, not a potency): 96%
Estimate against measurement, compound 4: 3 percentage points above, within the range that was stated.
By their numbers in this assay, from the lowest: compounds 4, 2, 1 and 3 (each within the scatter of the next).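

Within the data shown here, until this result, the groups compared at this position held carbon only, whereas acetyl also carries an oxygen, a double bond outside the aromatic ring and a hydrogen-bond acceptor. Even so, this assay shows a number 4 percentage points lower from compound 2 to compound 4 (within the scatter) and a number 5 percentage points lower from compound 1 to compound 4 (within the scatter) as its two new steps. At this concentration the read-out therefore does not separate ethyl, tert-butyl and acetyl on this aromatic carbon, and nothing available here bears on why that is so.

The compounds shown leave open whether an amine or a carboxylic acid at this position would move the read-out in this assay beyond the scatter. They also leave open whether a longer chain there would do so, or whether a change elsewhere on the shared core would.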